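Trifluoromethyl to fluoro at the assay limit

The compounds below may be only part of what the source reports. "The series", "measured", "known", "first", "only" and "open" are said of these compounds alone.

In an ADME assay on BJ cells (Homo sapiens) for cytotoxicity, read by luminescence, with a stated time of 72 h (on this read-out higher numbers stand for an effect only at larger amounts of compound and lower numbers for an effect already at smaller amounts), compound 3 `CCOC(=O)c1c(-c2cccc(C(F)(F)F)c2)[nH]c2cc(OC)ccc2c1=O` reads > 21500 nM as a limit of the assay and not a number. Compound 1 `CCCOc1cccc(-c2[nH]c3cc(OC)ccc3c(=O)c2C(=O)OCC)c1` reads > 21500 nM as a limit too. Compound 2 `CCOC(=O)c1c(-c2cccc(OCc3ccccc3)c2)[nH]c2cc(OC)ccc2c1=O` reads > 21500 nM as a limit as well. Compound 3 therefore stands at the limit of > 21500 nM in this assay, at which 3 of the 3 values shown sit, with no number to rank it.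

Compound 4 `CCOC(=O)c1c(-c2cccc(F)c2)[nH]c2cc(OC)ccc2c1=O` differs from compound 3 in one place: fluoro in place of trifluoromethyl on an aromatic carbon that is, fluoro in place of trifluoromethyl on an aromatic carbon. Among the compounds with values here, three measured steps bear on this, and none has a readable size: a step that the two limits leave unreadable from compound 1 to compound 3 with trifluoromethyl replacing propoxy, a step that the two limits leave unreadable from compound 2 to compound 3 with trifluoromethyl replacing benzyloxy, and a step that the two limits leave unreadable from compound 1 to compound 2 with phenyl replacing ethyl. None of the three compounds gives a number in this assay so no step beyond the scatter is expected, in either direction. The expected step is a step that the limit leaves unreadable from compound 3 to compound 4 and it rests on limits alone. Compound 4 is estimated at 30000 nM with an expected range from 15000 nM to 60000 nM and will probably be reported as a limit again.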

Compound 4, half-maximal effective concentration: > 21500 nM
Compound 4: a limit, no number; the forecaster's own chance of this, stated with the estimate: 90%; the middle value is on the limit's open side.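

In this assay, within the data shown here, compound 4 gives > 21500 nM as a limit of the assay and not a number, so no step from compound 1, compound 2 or compound 3 to compound 4 can be read. The compounds shown leave open whether in this assay the propoxy, benzyloxy, trifluoromethyl and fluoro compounds differ at all.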